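Swapping the sulfur group on an anilino-imidazoline

The compounds below may be only part of what the source reports. "The series", "measured", "known", "first", "only" and "open" are said of these compounds alone.

Of the compounds shown here, two have been measured in an assay for binding affinity to Alpha-1B adrenergic receptor (Homo sapiens), read by radioligand binding; on this read-out higher numbers stand for weaker inhibition and lower numbers for stronger inhibition. Compound 1, `CSc1ccc(F)cc1NCC1=NCCN1`, gives 40.7 nM. Compound 2, `CS(=O)(=O)c1ccc(Cl)cc1NCC1=NCCN1`, gives 2950 nM, the highest of the two numbers; its nearest neighbour is compound 1, whose number is lower by an amount well beyond the scatter. Within the data shown here, compound 1 and compound 2 differ in two places at once, so no single step is drawn between them.

Compound 3, `CSc1ccc(Cl)cc1NCC1=NCCN1`, is not yet measured. It arises from compound 2 by one change: methylsulfanyl in place of methylsulfonyl on an aromatic carbon. The methylsulfanyl group that enters is the same group that compound 1 carries, while the chloro group of compound 2 is kept. Since compound 1 with methylsulfanyl sits far lower than compound 2, a large drop toward compound 1 is expected. Compound 3 is therefore expected to give about 50 nM, between 10 nM and 300 nM. That estimate means an expected step of a 59-fold lower number from compound 2 to compound 3 (1.77 log units; beyond the scatter).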

Compound 3, inhibition constant: 69.2 nM
For compound 3 the middle estimate is 1.4-fold (0.14 log units) below the measured one; the range from low to high includes it.
By their numbers in this assay, from the lowest: compounds 1 and 3 (each within the scatter of the next); then compound 2.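

In this assay, the change of methylsulfonyl to methylsulfanyl on this aromatic carbon, para to a chloro group, gives a 43-fold lower number from compound 2 to compound 3 (1.63 log units; beyond the scatter) with everything else held the same, so this one position alone can carry a large step, something the earlier pair, differing in two places at once, could not show. The second single change, chloro in place of fluoro on an aromatic carbon, gives a 1.7-fold higher number from compound 1 to compound 3 (0.23 log units; within the scatter) and so cannot be told apart from the scatter when methylsulfanyl is present. Nothing here gives a measured reason for the size of the step at the sulfur group.

Still open, from the compounds shown here alone, is how other groups at this position would compare, such as methylsulfinyl, ethylsulfanyl, methoxy or an amine. Also open, going by these compounds, is whether the same sulfur change would give a step of similar size with fluoro in place of chloro.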